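This account rests on a few compounds, and the source may have more. Where it says the series, first, only, none or still open, it means among the compounds named here.

Series of arylpiperazine ureas, three members measured in an assay on CHO cells for displacement of a labelled ligand from D(4) dopamine receptor (Homo sapiens), read by radioligand binding; on this read-out higher numbers stand for weaker inhibition and lower numbers for stronger inhibition. Compound 1 `COc1ccccc1N1CCN(CCCCNC(=O)NN(Cc2ccccc2)c2ccc(F)cc2)CC1` gives 4.4 nM in this assay. Compound 2 `COc1ccc(N(Cc2ccc(F)cc2)NC(=O)NCCCN2CCN(c3ccccc3OC)CC2)cc1` gives 2.9 nM in this assay. Compound 3 `O=C(NCCCN1CCN(c2ccc(Cl)cc2)CC1)NN(Cc1ccccc1)c1ccccc1` gives 9.7 nM in this assay, the highest of the three numbers; its gap to compound 1 is beyond the scatter, and its gap to compound 2 is wider still and also beyond the scatter. No pair among these three differs in only one place, so no single-step comparison can be drawn from the measured set.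

The next compound, compound 4 `O=C(NCCCN1CCN(c2ccc(Br)cc2)CC1)NN(Cc1ccccc1)c1ccccc1`, differs from compound 3 by one exchange: bromo in place of chloro on an aromatic carbon. Nothing else in the two structures is altered. Among the measured compounds shown here, no measured pair shows the same exchange, so the size of its effect in this assay has to be judged without a precedent. The expectation is that the step from chloro to bromo at this aromatic carbon changes the number little, with a 1.1-fold lower number from compound 3 to compound 4 (0.03 log units; within the scatter) estimated to stay within the usual scatter and with no direction preferred. Compound 4 is therefore expected to give about 9 nM in this assay, with the plausible range running from 4 nM to 20 nM.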

Compound 4, inhibition constant: 14 nM
For compound 4 the middle estimate is 1.6-fold (0.19 log units) below the measured one; the range from low to high includes it.
By their numbers in this assay, from the lowest: compounds 2 and 1 (each within the scatter of the next); then compounds 3 and 4 (each within the scatter of the next).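

Among the compounds shown here, this is the first single-place comparison: in this assay, bromo in place of chloro on an aromatic carbon para to a large group gives a 1.4-fold higher number from compound 3 to compound 4 (0.16 log units; within the scatter). At this position, then, the read-out does not separate the 4-chlorophenyl from the 4-bromophenyl compound, and the exchange of one halogen for the other leaves the number inside the usual scatter, so no order can be assigned to this pair. Nothing measured beyond the numbers themselves bears on this result, and it stands as an observation without an explanation.

The compounds shown hold only chloro and bromo at this carbon, so the reach of the position remains open: a bare hydrogen, an iodo, an amine or a carboxylic acid there could read quite differently, and one pair says nothing about those groups. For the compounds shown here, also open is whether the same exchange reads the same way on a longer chain, as the step has been seen only on the chain shared by compound 3 and compound 4.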